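The source may hold more compounds than are shown below. What is called first, only, known or untested is meant among the compounds shown, and "the series" means these compounds.

Working notes on the series. All compounds share the core of compound 1 `CC(C)CSc1nc(N)nc2c1ncn2/C=C1/CC1(CO)CO` and differ at one aromatic carbon. In an ADME assay on HFF cells (Homo sapiens) for cytotoxicity, with a stated time of 8 days (on this read-out higher numbers stand for lower toxicity in this test and lower numbers for higher toxicity in this test), compound 1 gives > 300000 nM, which is a limit of the assay and not a number. Compound 2 `CCCNc1nc(N)nc2c1ncn2/C=C1/CC1(CO)CO` in this assay gives > 300000 nM, again a limit. Compound 3 `CCCCCCCCSc1nc(N)nc2c1ncn2/C=C1/CC1(CO)CO` in this assay gives > 300000 nM, also a limit. Compound 3 thus stands at the limit of > 300000 nM in this assay, at which 3 of the 3 values shown sit, and no order among the three compounds can be read. The measured changes at this carbon, a step that the two limits leave unreadable from compound 1 to compound 2 and a step that the two limits leave unreadable from compound 2 to compound 3, and the chain change a step that the two limits leave unreadable from compound 1 to compound 3, are all of unreadable size, the two limits hiding any step. Compound 4 `CNc1nc(N)nc2c1ncn2/C=C1/CC1(CO)CO` is to be measured in this assay. Its change from compound 3: methylamino in place of octylsulfanyl on an aromatic carbon. Among the measured compounds shown here, the steps that bear on it are those just named, none of which shows a readable size in either direction. Since compound 3 sits at the limit of > 300000 nM in this assay, at which 3 of the 3 values shown sit, the step of a number no higher from compound 3 to compound 4 (the limit leaves the size open) is expected to remain unreadable, with compound 4 most likely reported again as a limit. Compound 4 is estimated at 300000 nM, in the range 100000 nM to 1000000 nM.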

Compound 4, half-maximal cytotoxic concentration: 265000 nM
Beside the measured number, compound 4's estimate is 1.1-fold (0.05 log units) above it; the measured number falls inside the stated range.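

In this assay, among the compounds shown here, compound 4, with methylamino at this aromatic carbon, gives the first number of the series and not a limit, which sets a first measured point for this position. The three new steps are floors only (an at least 1.1-fold lower number from compound 3 to compound 4 (0.05 log units; that floor lies within the scatter)) (an at least 1.1-fold lower number from compound 2 to compound 4 (0.05 log units; that floor lies within the scatter)) (an at least 1.1-fold lower number from compound 1 to compound 4 (0.05 log units; that floor lies within the scatter)), so methylamino is not shown to differ beyond the scatter from octylsulfanyl, propylamino or isobutylsulfanyl, and the steps among compound 1, compound 2 and compound 3 still cannot be read. The true size of every step at this carbon stays hidden because the other compounds sit at the assay limit: the limit of > 300000 nM in this assay, at which 3 of the 4 values shown sit.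

The compounds shown leave open how large these steps are. They also leave open whether a benzylamino group or a carboxylic acid at this aromatic carbon would give a clearly lower number.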